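Adding One Fluoro Group to Compound 2

A few compounds are considered here, and "the series" means these few. Any claim that something is new, unique, unknown or untested is made for them only; others in the source may bear on it.

Of the compounds shown here, two have numbers so far in a functional assay on A549 cells (Homo sapiens) for cytotoxicity, read by MTT assay, with a stated time of 48 h; on this read-out lower numbers stand for stronger inhibition and higher numbers for weaker inhibition. There, compound 1 `COc1cc(COCc2cn(Cc3cc(C)cnc3Cl)nn2)cc(OC)c1OC` gives 41900 nM, and compound 2 `COc1cc(-c2cc(COCc3cn(Cc4cc(-c5ccccc5)cnc4Cl)nn3)on2)cc(OC)c1OC` gives 112000 nM. Compound 2 therefore holds the higher of the two numbers, meaning weaker inhibition, and the gap between them lies beyond the usual scatter. These two compounds differ in more than one place, so they say little about a single small change. Compound 3 `COc1cc(-c2cc(COCc3cn(Cc4cc(-c5ccc(F)cc5)cnc4Cl)nn3)on2)cc(OC)c1OC` matches compound 2 except at one spot: fluoro in place of hydrogen on an aromatic carbon. This is fluoro in place of hydrogen on an aromatic carbon, para to a large group, turning phenyl to 4-fluorophenyl. Among the measured compounds shown here, no measured pair shows what this swap does, so in this assay no shift beyond the scatter is expected. The expected change is a 1.2-fold lower number from compound 2 to compound 3 (0.07 log units; within the scatter). For compound 3 the estimated value is 95000 nM, with an expected range of 48000 nM to 190000 nM.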

Compound 3, half-maximal inhibitory concentration: 40600 nM
Estimate against measurement, compound 3: 2.3-fold (0.37 log units) above; measured number outside the range, below it.
By their numbers in this assay, from the lowest: compounds 3 and 1 (each within the scatter of the next); then compound 2.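

In this assay, among the compounds shown here, fluoro in place of hydrogen on an aromatic carbon, para to a large group, gives a 2.8-fold lower number from compound 2 to compound 3 (0.44 log units; beyond the scatter) and so provides the first single-place step in this small set. For the compounds shown here, only one atom changes in this step. It can be tied to one spot, which the gap between the first two compounds could not do. It shows that this position is sensitive, since adding one fluorine, turning phenyl to 4-fluorophenyl, moves the number beyond the usual scatter, but nothing measured here explains why.

Going by these compounds, what an amine, a nitrile or a trifluoromethyl group would do on this same carbon remains open, so it cannot yet be said whether the step is specific to fluoro. On these data alone, whether fluoro would have a similar effect on other aromatic carbons of the shared core also remains unknown.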